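The source may hold more compounds than are shown below. What is called first, only, known or untested is meant among the compounds shown, and "the series" means these compounds.

Of the compounds shown here, three have been read in an ADME assay on a cell-free system (serum) for metabolic stability (on this read-out higher numbers stand for a longer-lived compound and lower numbers for a shorter-lived compound), and none of them has yet given a number. Compound 1 `CC(C)(C)c1cc(NC(=O)c2ccc(Cl)cc2Cl)cc(C(C)(C)C)c1O` gives > 1 h, which is a limit of the assay. Compound 2 `CC(C)c1cc(NC(=O)c2ccc(Cl)cc2Cl)ccc1O` gives > 1 h, which is again a limit. Compound 3 `CC(C)(C)c1cc(NC(=O)c2c(Cl)cc(NCc3ccncc3)cc2Cl)ccc1O` gives > 1 h, and this too is a limit rather than a number. Compound 3 therefore has no exact place on the scale, and the whole evidence is the limit of > 1 h in this assay, at which 3 of the 3 values shown sit.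

Compound 4 `CN(c1cc(Cl)c(C(=O)Nc2ccc(O)c(C(C)(C)C)c2)c(Cl)c1)C1CCCCC1` comes from compound 3 through a single change, (cyclohexyl(methyl)amino in place of ((pyridin-4-yl)methyl)amino on an aromatic carbon). Cyclohexyl(methyl)amino stands in place of ((pyridin-4-yl)methyl)amino on an aromatic carbon, meta to two chloro groups and para to a large group.

Within the data shown here, no two measured compounds differ in only one place, so the data give no direct measure of such a step. No change beyond the usual scatter is expected in this assay, in either direction, because of the limit of > 1 h in this assay, at which 3 of the 3 values shown sit. The expected step is a step that the limit leaves unreadable from compound 3 to compound 4. Compound 4 may well be reported only as a limit too. For compound 4 the estimated half-life is 2 h, with an expected range of 1 h to 8 h.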

Compound 4, half-life: > 1 h
Compound 4: only a limit was reported; the forecaster's own chance of this, stated with the estimate: 75%; the middle value does not contradict the limit.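

In this assay compound 4 gives > 1 h as a limit and not a number. Compound 3 also stands at a limit, so no step can be read between compound 3 and compound 4. The compounds shown leave open how their half-lives compare, because none of them has given a number: the limit of > 1 h in this assay, at which 4 of the 4 values shown sit.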